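Shifting the hydroxyl on a topoisomerase inhibitor scaffold

A few compounds are considered here, and "the series" means these few. Any claim that something is new, unique, unknown or untested is made for them only; others in the source may bear on it.

Measured compounds:
compound 1, `Oc1cccc(-c2cc(-c3cccnc3)nc(-c3cccc(Cl)c3)c2)c1` — 27.6%
compound 2, `Oc1cccc(-c2cc(-c3cccnc3)nc(-c3ccccc3Cl)c2)c1` — 0%

In an assay on isolated protein for inhibition of DNA topoisomerase 1 (Homo sapiens), with a stated time of 30 min, tested at 100 uM (a lower number here means a weaker effect, a higher number a stronger effect of the compound at the concentration tested), compound 1 gives 27.6%. In this assay, among the measured compounds shown here, compound 2 gives 0%, the lowest of the two numbers; its nearest neighbour is compound 1, and the only measured step, a number 27.6 percentage points lower from compound 1 to compound 2 (beyond the scatter), comes with 2-chlorophenyl in place of 3-chlorophenyl on an aromatic carbon. Compound 3, `Oc1ccc(-c2cc(-c3cccnc3)nc(-c3ccccc3Cl)c2)cc1`, differs from compound 2 in another way: 4-hydroxyphenyl in place of 3-hydroxyphenyl on an aromatic carbon.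

For the measured compounds named here, no measured step touches the hydroxyphenyl group, so the chlorophenyl step gives no guide to how the change from compound 2 to compound 3 will read out. With nothing pointing in either direction, no step beyond the scatter is expected, and the estimated step is a number 5 percentage points higher from compound 2 to compound 3 (within the scatter). Compound 3 is therefore expected to give about 5%, within a range from 0% to 25%, with the upper end allowing for the chance that the moved hydroxyl recovers some inhibition.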

Compound 3, a percentage reported as inhibition, at one concentration (the size of the read-out at that concentration, not a potency): 0.9%
The estimate for compound 3 lay 4.1 percentage points above the measured number; measured number inside the range.
By their numbers in this assay, from the lowest: compounds 2 and 3 (each within the scatter of the next); then compound 1.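

In this assay, 4-hydroxyphenyl in place of 3-hydroxyphenyl gives a number 0.9 percentage points higher from compound 2 to compound 3 (within the scatter), so at this place, opposite the ring nitrogen, the two groups cannot be told apart while the 2-chlorophenyl group is present. Among the compounds shown here, the earlier compounds showed only a step at the chlorophenyl group; this is the first reading at the hydroxyphenyl group, and it starts from compound 2 at 0%, which leaves little room to detect any loss, so the result shows only that the shift brings back no inhibition beyond the scatter. Nothing at hand explains this result.

The compounds shown leave open whether the same shift would matter with the 3-chlorophenyl group, the setting in which compound 1 gives 27.6% and a loss could be read as well as a gain. They also leave open whether the hydroxyl itself counts for anything at this place, which an amine, a methoxy group or a carboxylic acid on the same phenyl ring could test.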